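A few compounds are considered here, and "the series" means these few. Any claim that something is new, unique, unknown or untested is made for them only; others in the source may bear on it.

Notes on the series in an ADME assay on SH-SY5Y cells (Homo sapiens) for cytotoxicity, read by MTT assay, with a stated time of 48 h; a lower number here means a stronger inhibitor, a higher number a weaker inhibitor. Compound 1 `COc1ccc(C(=O)/C=C/c2ccc(C(=O)N(C)c3ccccc3)cc2)c(O)c1` carries methyl(phenyl)amino on the carbonyl carbon. In this assay compound 1 gives > 100000 nM, which is a limit of the assay rather than a number. Compound 2 `CCCNC(=O)c1ccc(/C=C/C(=O)c2ccc(OC)cc2O)cc1` has propylamino in that place. In this assay compound 2 gives > 100000 nM, again a limit. Compound 3 `COc1ccc(C(=O)/C=C/c2ccc(C(=O)O)cc2)c(O)c1` bears hydroxy on the carbonyl carbon. In this assay compound 3 gives > 100000 nM, also a limit. Compound 3 thus stands at the same limit as the other two members, as the limit of > 100000 nM in this assay, at which 3 of the 3 values shown sit, records, and none of the three can be ordered against another. The steps a step that the two limits leave unreadable from compound 1 to compound 2, a step that the two limits leave unreadable from compound 1 to compound 3 and a step that the two limits leave unreadable from compound 2 to compound 3 are accordingly unreadable in size and direction. Compound 4 `COc1ccc(C(=O)/C=C/c2ccc(C(=O)N3CCCC3)cc2)c(O)c1` is the next member; it differs from compound 3 by pyrrolidin-1-yl in place of hydroxy on a carbonyl carbon. The measured steps that bear on it, all exchanges on the same carbonyl carbon, carry no readable size, so neither a direction nor a magnitude can be drawn from them. The step of a number no higher from compound 3 to compound 4 (the limit leaves the size open) is expected to stay within the scatter, with a limit the most likely outcome. Compound 4 is expected to give about 100000 nM, between 30000 nM and 300000 nM.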

Compound 4, half-maximal inhibitory concentration: > 100000 nM
Compound 4 gave a limit, no number (the forecaster's own chance of this, stated with the estimate: 80%); the middle value sits exactly at the limit.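

No new step can be read in this assay from compound 4 against compound 1, compound 2 or compound 3, and all four compounds share one limit: the limit of > 100000 nM in this assay, at which 4 of the 4 values shown sit. The compounds shown leave open whether any exchange on the carbonyl carbon shifts the read-out in this assay at all, and in which direction.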